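The source may report more compounds than this note shows. Statements on the series, on what has been measured and on what is new or still open speak of the compounds shown alone.

Of the compounds shown here, two have so far been tested in an ADME assay on BEAS-2B cells (Homo sapiens) for cytotoxicity, read by MTT assay, with a stated time of 72 h; a higher number here means a weaker inhibitor of growth, a lower number a stronger inhibitor of growth. Compound 1 `CSc1ccc(CNc2nc(SC)nc3ncccc23)cc1` gives 600 nM in this assay. Compound 2 `Sc1nc(NCc2ccccc2)c2ccccc2n1` gives 66300 nM in this assay. Compound 1 thus stands lowest of the two numbers, and its gap to compound 2 lies well beyond the scatter of repeated measurements. For the measured compounds named here, compound 2 differs from compound 1 in several places at once, so the pair alone shows only that the two numbers differ widely; it does not isolate any single change.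

Compound 3 `CSc1nc(NCc2ccccc2)c2cccnc2n1` has not yet been measured. It differs from compound 1 in one place: hydrogen in place of methylsulfanyl on an aromatic carbon, in words, hydrogen in place of methylsulfanyl on an aromatic carbon. Going by the values given here, no pair of measured compounds shows this change by itself, so the size of the step is open, and only a guess can be made. The expectation is a modest rise in the number, with the step from compound 1 to compound 3 estimated as a 2.5-fold higher number from compound 1 to compound 3 (0.40 log units; beyond the scatter). On that basis compound 3 is expected to give about 1500 nM in this assay, with a likely range from 300 nM to 8000 nM.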

Compound 3, concentration for 50% growth inhibition: 25900 nM
Beside the measured number, compound 3's estimate is 17-fold (1.24 log units) below it; measured number above the stated range.
By their numbers in this assay, from the lowest: compound 1; then compound 3; then compound 2.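

In this assay, replacing methylsulfanyl with hydrogen on the six-membered aromatic ring of carbon only, para to a large group, gives a 43-fold higher number from compound 1 to compound 3 (1.64 log units; beyond the scatter). The earlier pair differed in several places at once and could not isolate any single change, whereas this pair shows that one change at this position is enough to produce a large step, with the loss of methylsulfanyl going with much weaker growth inhibition in these cells. No measurement at hand bears on why the step is so large.

Only hydrogen and methylsulfanyl are shown at this position, so it remains open whether the low number depends on methylsulfanyl itself or whether other groups there would give a similar result. A methoxy group, a chlorine atom or a longer chain such as ethylsulfanyl in the same place could show whether the number stays near that of compound 1, at 600 nM, or rises towards that of the compound carrying hydrogen.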